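Alkyne substituent swap on the shared core: thiophene to hydroxycyclohexyl

The compounds below may be only part of what the source reports. "The series", "measured", "known", "first", "only" and "open" are said of these compounds alone.

Compound 1 `O=[N+]([O-])c1c(CS(=O)(=O)c2ccccc2)nc2c(C#Cc3cccs3)cc(Cl)cn12` carries a 2-(thiophen-2-yl)ethynyl group on the shared core. In an ADME assay on HepG2 cells (Homo sapiens) for cytotoxicity, read by MTT assay, with a stated time of 72 h (a lower number here means that less compound is tolerated, a higher number that more compound is tolerated), compound 1 gives only a limit, > 3900 nM. Compound 2 `O=[N+]([O-])c1c(CS(=O)(=O)c2ccccc2)nc2c(C#CCCO)cc(Cl)cn12` likewise gives only a limit in this assay, > 125000 nM. Compound 3 `CC(O)C#Cc1cc(Cl)cn2c([N+](=O)[O-])c(CS(=O)(=O)c3ccccc3)nc12` gives 44200 nM in this assay. Both steps from compound 1 are therefore unreadable: a step that the two limits leave unreadable from compound 1 to compound 2 and a step that the limit leaves unreadable from compound 1 to compound 3. Among the measured compounds shown here, the one readable step is an at least 2.8-fold lower number from compound 2 to compound 3 (0.45 log units; beyond the scatter). Compound 1 thus stands only as a limit among the three values, and its place relative to compound 2 and compound 3 cannot be read.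

Compound 4 `O=[N+]([O-])c1c(CS(=O)(=O)c2ccccc2)nc2c(C#CC3(O)CCCCC3)cc(Cl)cn12` differs from compound 1 by 1-hydroxycyclohexyl in place of thiophen-2-yl on a triple-bonded carbon. For the measured compounds named here, no measured step carries a 1-hydroxycyclohexyl group; the nearest comparison is compound 3 with its 1-hydroxyethyl, at 44200 nM, which also puts a hydroxyl-bearing group on a triple-bonded carbon. The expectation for compound 4 is therefore a number near that of compound 3, estimated at 25000 nM with a range of 6000 nM to 100000 nM. Against compound 1 this would mean an expected step that the limit leaves unreadable from compound 1 to compound 4.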

Compound 4, half-maximal cytotoxic concentration: > 25000 nM
Compound 4: a limit, no number; the forecaster's own chance of this, stated with the estimate: 35%; the middle value lies on the limit itself.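

In this assay, among the compounds shown here, compound 4 gives only a limit, so no step between compound 4 and compound 1, compound 2 or compound 3 can be read. The compounds shown leave open where compound 1 and compound 4 stand relative to compound 2 and compound 3.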